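Swapping a Phenyl for a Hexyl on the Ring Nitrogen

The compounds below may be only part of what the source reports. "The series", "measured", "known", "first", "only" and "open" are said of these compounds alone.

Of the compounds shown here, three sharing one core have been tested in a functional assay on A549 cells (Homo sapiens) for antiproliferative activity, read by trypan blue exclusion, with a stated time of 72 h, tested at 20 uM; a higher number here means more inhibition at the concentration tested (going by the name of the read-out), a lower number less inhibition. Compound 1 `CCCCN1C(=O)NC(=O)/C1=C/c1ccccc1` gives 18%. Compound 2 `O=C1NC(=O)N(c2ccccc2)/C1=C/c1ccccc1` gives 18%. Compound 3 `O=C1NC(=O)N(c2ccccc2)/C1=C\c1ccccc1` gives 26%. The steps of a number 8 percentage points higher from compound 1 to compound 3 (within the scatter) and a number 8 percentage points higher from compound 2 to compound 3 (within the scatter) both lie within the usual scatter, so the three numbers cannot be told apart, and compound 3 stands level with the other two. The second of these steps rests on (the fact that compounds 2 and 3 differ only in the configuration as drawn).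

Compound 4 `CCCCCCN1C(=O)NC(=O)/C1=C/c1ccccc1` has not yet been measured. It differs from compound 3 by hexyl in place of phenyl on an amide-type nitrogen in a ring. Among the measured compounds shown here, the one measured step that bears on this change is the exchange of butyl for phenyl at the same ring nitrogen, a number 8 percentage points higher from compound 1 to compound 3 (within the scatter), which stayed within the scatter. For the measured compounds named here, no measured step covers hexyl itself, so a step of no more than the scatter is expected in this assay. Compound 4 is therefore expected to give 20%, in a range from 6% to 34%, which means an expected step of a number 6 percentage points lower from compound 3 to compound 4 (within the scatter).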

Compound 4, a percentage reported as inhibition, at one concentration (the size of the read-out at that concentration, not a potency): 0%
For compound 4 the middle estimate is 20 percentage points above the measured one; the measured number lies below the stated range.
By their numbers in this assay, from the lowest: compound 4; then compounds 1, 2 and 3 (each within the scatter of the next).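

In this assay, among the compounds shown here, this ring nitrogen proves sensitive to the group it carries, something the earlier compounds could not show because their numbers stayed within the scatter of one another. Exchanging phenyl for hexyl gives a number 26 percentage points lower from compound 3 to compound 4 (beyond the scatter), and extending butyl to hexyl gives a number 18 percentage points lower from compound 1 to compound 4 (beyond the scatter), so in this small set a change at this position now clearly registers, both when a ring gives way to an open chain of equal heavy-atom count and when the chain simply grows. Nothing known about these compounds accounts for the loss of inhibition.

Going by these compounds, whether inhibition fades gradually or abruptly as the chain grows remains open, and pentyl would sit between butyl and hexyl. On these data alone, it is also open whether an amine or a carboxylic acid at the end of the hexyl chain would bring inhibition back.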